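The source may report more compounds than this note shows. Statements on the series, on what has been measured and on what is new or still open speak of the compounds shown alone.

Compound 1 `CC(Sc1nnc(-c2ccncc2)s1)C(=O)Nc1ccccc1`: in an ADME assay on HepG2 cells (Homo sapiens) for cytotoxicity, with a stated time of 3 days (on this read-out higher numbers stand for lower toxicity in this test and lower numbers for higher toxicity in this test), compound 1 gives > 50000 nM, a limit of the assay.
Compound 2 `CC(Sc1nnc(-c2ccncc2)s1)C(=O)Nc1ccc(Cl)cc1`: compound 2 gives > 50000 nM, likewise a limit.
Among the measured compounds shown here, compound 3 `O=C(CCSc1nnc(-c2ccncc2)s1)NCc1ccccc1`: compound 3 gives 14000 nM, the only number among the three.

From compound 1 to compound 2 the change is chloro in place of hydrogen on an aromatic carbon. The resulting step, a step that the two limits leave unreadable from compound 1 to compound 2, cannot be read because the limit of > 50000 nM in this assay, at which 2 of the 3 values shown sit, holds both ends. The difference between the core of compound 1 and that of compound 3 is not broken down here. Compound 4 `O=C(CCSc1nnc(-c2ccncc2)s1)NCc1ccc(Cl)cc1` is unmeasured and carries the same change as compound 2, namely (chloro in place of hydrogen on an aromatic carbon). Since the measured pair gives no usable size, the expectation for compound 4 leans on compound 3 alone with 14000 nM as anchor, and a step of a 1.4-fold lower number from compound 3 to compound 4 (0.15 log units; within the scatter) is estimated. Compound 4 is thus expected to give about 10000 nM in this assay, within 4000 nM to 30000 nM.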

Compound 4, half-maximal cytotoxic concentration: 15600 nM
Beside the measured number, compound 4's estimate is 1.6-fold (0.19 log units) below it; measured number inside the range.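

In this assay, chloro in place of hydrogen on the core of compound 3, phenyl to 4-chlorophenyl within a benzyl group, gives a 1.1-fold higher number from compound 3 to compound 4 (0.05 log units; within the scatter), so on this core the change leaves the read-out within the scatter. The same change on the core of compound 1 cannot be read, because both of its ends sit at a limit: the limit of > 50000 nM in this assay, at which 2 of the 4 values shown sit. Carrying the change from one core to the other is therefore neither confirmed nor contradicted, and the only readable result comes from a single pair on a single core.

The compounds shown leave open how an amine or a carboxylic acid at the same place on the aromatic ring would read in this assay. Also open, going by these compounds, is whether a longer chain on the core of compound 3 would shift the value.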